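From benzoyl to (1H-pyrazol-4-yl)carbonyl on a shared core

This account rests on a few compounds, and the source may have more. Where it says the series, first, only, none or still open, it means among the compounds named here.

Going by the values given here, in a physicochemical assay for lipophilicity, read by HPLC, measured as chromatographic lipophilicity, at pH 7.4 (a higher number here means a more lipophilic compound, a lower number a more polar compound), compound 1 (`O=C(c1ccccc1)N1CCC(C(=O)N2N=CCC2c2ccccc2)CC1`) gives 4.4 and holds the lower of the two numbers available so far. Compound 2 (`CC(C)(C)C(=O)N1CCC1c1ccccc1`) gives 5 in the same measurement, and that gap lies beyond the scatter. These two compounds differ in more than one place, so their gap says nothing about any single structural change.

Compound 3 (`O=C(c1cn[nH]c1)N1CCC(C(=O)N2N=CCC2c2ccccc2)CC1`) keeps the core of compound 1 and differs from it in one place, with 1H-pyrazol-4-yl in place of phenyl on a carbonyl carbon. Among the compounds with values here, no measured pair shows this change, so the expectation rests on the structural change alone, with compound 1 at 4.4 as the starting point. The estimated step of a number 1.20 log units lower from compound 1 to compound 3 (beyond the scatter) in this assay is expected to be downward and clearly beyond the scatter. Compound 3 is expected at 3.2 with an estimated range from 2.7 to 3.7 awaiting the measurement.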

Compound 3, distribution coefficient: 2.1
Beside the measured number, compound 3's estimate is 1.10 log units above it; the measured number lies below the stated range.
By their numbers in this assay, from the lowest: compound 3; then compound 1; then compound 2.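

The series now has its first single-place step: in this assay, 1H-pyrazol-4-yl in place of phenyl on a carbonyl carbon, with the shared core otherwise unchanged, gives a number 2.30 log units lower from compound 1 to compound 3 (beyond the scatter) and marks this position as one where the read-out can move a long way. The swap changes several counted features at once, since a six-membered aromatic ring of carbon only gives way to a five-membered aromatic ring with hetero atoms that also carries a hydrogen-bond donor and a hydrogen-bond acceptor, and this single pair cannot divide the step among those features. Nothing on hand bears on why the step has this size.

Still open, on these data alone, is how a 1-methyl-1H-pyrazol-4-yl or a pyridin-3-yl group on the same carbonyl carbon would read in this assay, and with it whether the step follows the ring size, the ring nitrogens or the hydrogen on the ring nitrogen. Also open, as far as these compounds go, is whether a step of this size would recur on another core, as the change is seen here in one pair only.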